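Iodo in place of ethyl on the sulfonamide aryl ring

This account rests on a few compounds, and the source may have more. Where it says the series, first, only, none or still open, it means among the compounds named here.

Compound 1 `CCc1ccccc1NS(=O)(=O)c1ccc(N2CCNC2=O)cc1`: 240 nM
Compound 2 `CCc1ccc(NS(=O)(=O)c2ccc(N3CCNC3=O)cc2)cc1`: 660 nM
Compound 3 `COc1ccccc1NS(=O)(=O)c1ccc(N2CCNC2=O)cc1`: 550 nM

Three compounds built on one shared core were measured in a functional assay on HT-29 cells (Homo sapiens) for antiproliferative activity, read by sulforhodamine B assay, with a stated time of 48 h; on this read-out higher numbers stand for weaker inhibition and lower numbers for stronger inhibition. Compound 2 carries the highest number of the three. Its nearest neighbour is compound 3, and the step of a 1.2-fold lower number from compound 2 to compound 3 (0.08 log units; within the scatter) lies within the scatter, whereas the step of a 2.8-fold higher number from compound 1 to compound 2 (0.44 log units; beyond the scatter) lies beyond it, so compound 2 is separated only from compound 1.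

Compound 4 `O=C1NCCN1c1ccc(S(=O)(=O)Nc2ccc(I)cc2)cc1` has not yet been measured. The change from compound 2 to compound 4 is iodo in place of ethyl on an aromatic carbon. Within the data shown here, no measured step exchanges ethyl for iodo, so the guidance is indirect. The available steps are a 2.8-fold higher number from compound 1 to compound 2 (0.44 log units; beyond the scatter) and a 2.3-fold higher number from compound 1 to compound 3 (0.36 log units; beyond the scatter): both are modest, and they show that altering the group on the sulfonamide aryl ring, or where it sits, shifts the number only by a small amount in this series of three. A single exchange of ethyl for iodo on an aromatic carbon is therefore expected to leave the number close to that of compound 2, and the expected step of a 1.2-fold lower number from compound 2 to compound 4 (0.08 log units; within the scatter) is judged to fall within the scatter, with a slight lean toward a lower number. Compound 4 is accordingly estimated at 550 nM, within a range from 200 nM to 1500 nM.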

Compound 4, half-maximal inhibitory concentration: 650 nM
Beside the measured number, compound 4's estimate is 1.2-fold (0.07 log units) below it, within the range that was stated.
By their numbers in this assay, from the lowest: compound 1; then compounds 3, 4 and 2 (each within the scatter of the next).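

In this assay, among these compounds, the step of a 1.0-fold lower number from compound 2 to compound 4 (0.01 log units; within the scatter) is the first measured exchange of ethyl for iodo on this aromatic carbon para to a large group, and it lies within the scatter: with two carbon atoms leaving and one iodine entering, the two compounds cannot be told apart here. The step of a 1.2-fold higher number from compound 3 to compound 4 (0.07 log units; within the scatter) also lies within the scatter, whereas the step of a 2.7-fold higher number from compound 1 to compound 4 (0.43 log units; beyond the scatter) lies beyond it, so the 4-iodophenyl compound joins the 4-ethylphenyl and 2-methoxyphenyl compounds, and compound 1 remains the only one separated from the others. Nothing at hand bears on the reason for this result.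

The compounds shown leave open whether iodo would match ethyl on the ring position it occupies in compound 1, where the only comparison available is with the 2-methoxyphenyl compound. They also leave open whether an amine or a carboxylic acid on the carbon para to a large group would stay within the scatter of compound 4, or whether this carbon accepts only groups such as ethyl and iodo.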